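The source may report more compounds than this note shows. Statements on the series, on what has been measured and on what is new or still open speak of the compounds shown alone.

Working notes on the series. Compound 1 `CCOc1cc2[nH]c(Cc3nn(CC(=O)N4CCOCC4)c(=O)c4ccccc34)nc2cc1Cl`, compound 2 `CC(C)(C(=O)O)c1nn(Cc2cn3cc(OCC4CC4)c(Cl)cc3n2)c2ccccc2c1=O` and compound 3 `COc1cc(OC)c(NC(=O)Cc2nn(CC(=O)O)c(=O)c3ccccc23)cc1Cl` have been tested in a functional assay on CHO cells for antagonist activity at sphingosine 1-phosphate receptor 2 (Homo sapiens), read by calcium flux; a higher number here means a weaker inhibitor, a lower number a stronger inhibitor. In this assay compound 1 gives 10 nM, compound 2 gives 7.7 nM and compound 3 gives 186 nM. Compound 2 holds the lowest of the three numbers, but its gap to compound 1 lies within the scatter of repeated measurements, so no order between those two can be read; only the gap to compound 3 is beyond the scatter, and compound 3 is built on a different core, so nothing is drawn from that pair beyond what the two values show.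

Compound 4 `O=C(O)Cc1nn(Cc2cn3cc(OCC4CC4)c(Cl)cc3n2)c2ccccc2c1=O` differs from compound 2 in one place: carboxymethyl in place of 1-carboxy-1-methylethyl on an aromatic carbon. Going by the values given here, no measured pair in this set isolates this change, so the size of the step in this assay is open. The expectation is a step from compound 2 to compound 4 of a 2.3-fold higher number from compound 2 to compound 4 (0.37 log units; beyond the scatter), toward a somewhat weaker inhibitor or none beyond the scatter. Compound 4 is therefore estimated at 18 nM, within a range from 6 nM to 60 nM.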

Compound 4, half-maximal inhibitory concentration: 20 nM
Compound 4: middle estimate off by 1.1-fold (0.05 log units), on the low side; the range from low to high includes it.
By their numbers in this assay, from the lowest: compounds 2, 1 and 4 (each within the scatter of the next, the first and the last beyond it); then compound 3.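

In this assay, going by these compounds alone, carboxymethyl in place of 1-carboxy-1-methylethyl on this aromatic carbon gives a 2.6-fold higher number from compound 2 to compound 4 (0.41 log units; beyond the scatter), the first step in this set that isolates a change at this position. The step is modest: with the carboxylic acid kept and the two methyl groups gone, compound 4 still gives 20 nM, so the two methyl groups account for only a small part of the activity on this core. No measured property bears on this step, so it comes without an explanation.

From the compounds shown here alone, the effect of a single methyl, as in 1-carboxyethyl, remains open, so it is unclear whether the step would divide evenly between the two methyl groups. Also open, going by these compounds, is whether the carboxylic acid itself matters at this position on this core, which a primary amide or a tetrazole there would test.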